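This account rests on a few compounds, and the source may have more. Where it says the series, first, only, none or still open, it means among the compounds named here.

Measured compounds:
compound 1 `CC(Oc1cccnc1Nc1cnn(C)c1)c1cccc(C(=O)NCc2ccc(F)cc2)c1`
compound 2 `COc1cccc(CNC(=O)c2cccc(C(C)Oc3cccnc3Nc3cnn(C)c3)c2)c1`
compound 3 `CC(Oc1cccnc1Nc1cnn(C)c1)c1cccc(C(=O)NCc2ccc(F)c(Cl)c2)c1`

In a functional assay on NCI-H3122 cells (Homo sapiens) for antiproliferative activity, read by MTT assay, with a stated time of 48 h (on this read-out lower numbers stand for stronger inhibition and higher numbers for weaker inhibition), compound 1 gives 43800 nM, compound 2 gives 49400 nM and compound 3 gives 35700 nM. Compound 2 holds the highest of the three numbers, yet every step among them is within the scatter: a 1.1-fold higher number from compound 1 to compound 2 (0.05 log units; within the scatter), a 1.2-fold lower number from compound 1 to compound 3 (0.09 log units; within the scatter) and a 1.4-fold lower number from compound 2 to compound 3 (0.14 log units; within the scatter). Compound 4 `CC(Oc1cccnc1Nc1cnn(C)c1)c1cccc(C(=O)NCc2ccccc2S(=O)(=O)C(C)C)c1` differs from compound 2 by 2-(isopropylsulfonyl)phenyl in place of 3-methoxyphenyl on a saturated chain carbon bound to an amide-type nitrogen. Going by the values given here, the steps that bear on this are the two exchanges of the aryl group on the saturated chain carbon, and both stayed within the scatter; no measured step introduces a sulfonyl-bearing aryl. The expected step is therefore none beyond the scatter, a 1.1-fold lower number from compound 2 to compound 4 (0.04 log units; within the scatter). Compound 4 is estimated at 45000 nM, with a range from 15000 nM to 130000 nM.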

Compound 4, half-maximal inhibitory concentration: > 100000 nM
Compound 4: no number, only a limit; the forecaster's own chance of this, stated with the estimate: 20%; middle value at least 2.2-fold (0.34 log units) from the limit.
By their numbers in this assay, from the lowest: compounds 3, 1 and 2 (each within the scatter of the next). At a limit, above all of these: compound 4.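

On a saturated chain carbon bound to an amide-type nitrogen, 2-(isopropylsulfonyl)phenyl is the only aryl exchange shown that moves the read-out past the scatter in this assay: an at least 2.8-fold higher number from compound 3 to compound 4 (0.44 log units; beyond the scatter) and an at least 2.2-fold higher number from compound 1 to compound 4 (0.35 log units; beyond the scatter). The remaining step, an at least 2.0-fold higher number from compound 2 to compound 4 (0.30 log units; that floor lies within the scatter), gives only a floor, and that floor lies within the scatter. Compound 4 has a limit rather than a number, so the full size of these steps stays unknown: the limit of > 100000 nM in this assay, at which 1 of the 4 values shown sits.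

Still open, on these data alone, is whether the sulfonyl or the isopropyl carries this step. Also open, as far as these compounds go, is how an aryl group bearing a methylsulfonyl or an amine would read at this place.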